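The compounds below may be only part of what the source reports. "The series", "measured", "known", "first", "only" and "open" are said of these compounds alone.

Compound 1 `CC(=O)Oc1ccc(/C=C/C(=O)OCCSc2nc(-c3ccc(S(N)(=O)=O)cc3)n(-c3ccc(Br)cc3)n2)cc1OC(C)=O` and compound 2 `CC(=O)Oc1ccc(/C=C/C(=O)OCCSc2nc(-c3ccc(S(N)(=O)=O)cc3)n(-c3ccc(F)cc3)n2)cc1OC(C)=O` share one core and differ in a single place: fluoro in place of bromo on an aromatic carbon. In an assay on cells (strain Sprague-Dawley) for inhibition of Polyunsaturated fatty acid 5-lipoxygenase (Rattus norvegicus), with a stated time of 30 min (on this read-out lower numbers stand for stronger inhibition and higher numbers for weaker inhibition), compound 1 gives 1050 nM, and compound 2 gives 1060 nM, a step of a 1.0-fold higher number from compound 1 to compound 2 (0.00 log units; within the scatter). Compound 3 `CS(=O)(=O)c1ccc(-c2nc(SCCCOC(=O)/C=C/c3ccc(O)c(O)c3)nn2-c2ccc(Br)cc2)cc1` rests on a different core; how the two cores differ is not broken down here. In this assay compound 3 gives 790 nM, which lies within the scatter of both compound 1 and compound 2. Compound 4 `CS(=O)(=O)c1ccc(-c2nc(SCCCOC(=O)/C=C/c3ccc(O)c(O)c3)nn2-c2ccc(F)cc2)cc1` carries the same change relative to compound 3: fluoro in place of bromo on an aromatic carbon. The surroundings of the change are described in identical words for both pairs, so the same step is expected. Because the earlier step was a 1.0-fold higher number from compound 1 to compound 2 (0.00 log units; within the scatter), compound 4 is expected to show a 1.0-fold higher number from compound 3 to compound 4 (0.01 log units; within the scatter). Compound 4 is therefore estimated at 800 nM, with a likely range from 400 nM to 1600 nM.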

Compound 4, half-maximal inhibitory concentration: 710 nM
For compound 4 the middle estimate is 1.1-fold (0.05 log units) above the measured one; measured number inside the range.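

In this assay, fluoro in place of bromo on the second core gives a 1.1-fold lower number from compound 3 to compound 4 (0.05 log units; within the scatter). Set beside the earlier pair, the change carries from one core to the other with no difference that can be told from noise: the same change on two cores in this assay, a 1.0-fold higher number (0.00 log units; within the scatter) from compound 1 to compound 2 and a 1.1-fold lower number (0.05 log units; within the scatter) from compound 3 to compound 4, 1.1-fold (0.05 log units) apart, within the scatter of two such steps. This shows that 4-bromophenyl and 4-fluorophenyl give values within the scatter of each other on these two cores in this one assay, but it does not show that the same would hold on any other core.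

The compounds shown leave open whether a methoxy group, an amine or a carboxylic acid in this place would move the number beyond the scatter. They also leave open how a hydrogen or a chloro there would compare.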